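The source may report more compounds than this note shows. Statements on the series, on what has been measured and on what is new or still open speak of the compounds shown alone.

Working notes on the series. Compound 1 `CCCCCCCCCO[C@@H]1[C@@H](N)[C@@H](OCC(O)CNCCCO)O[C@H](CN)[C@H]1OCCCCCCCCC` and compound 2 `CCCCCCCCCO[C@@H]1[C@@H](N)[C@@H](O[C@H]2[C@H](O)[C@@H](O)[C@H](N)C[C@@H]2N)O[C@H](CN)[C@H]1OCCCCCCCCC` share one core and differ only in the group on an oxygen on a saturated carbon. In a toxicity assay on the whole organism (J774 cells) for cytotoxicity, with Mus musculus as the target, read by MTT assay, with a stated time of 24 h, tested at 10 uM (a higher number here means a weaker effect of the compound at the concentration tested, a lower number a stronger effect), compound 1 gives 89.9%. In this assay, among the compounds with values here, compound 2 gives 82.7%, the lower of the two numbers in hand; the single recorded step, a number 7.2 percentage points lower from compound 1 to compound 2 (within the scatter), stays within the scatter, so compound 1 and compound 2 cannot be ordered on this read-out.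

Compound 3 `CCCCCCCCCO[C@@H]1[C@@H](N)[C@@H](OCC(O)CO)O[C@H](CN)[C@H]1OCCCCCCCCC` is the next member. Against compound 2 the change is 2,3-dihydroxypropyl in place of 4,6-diamino-2,3-dihydroxycyclohexyl on an oxygen on a saturated carbon. Within the data shown here, the only measured step that bears on this exchange is the one that also replaced the group on an oxygen on a saturated carbon, a number 7.2 percentage points lower from compound 1 to compound 2 (within the scatter), and that exchange, which likewise removed or installed the 4,6-diamino-2,3-dihydroxycyclohexyl group, gave no movement beyond the scatter. Nothing measured suggests the 2,3-dihydroxypropyl group should behave differently. For compound 3 the expected step in this assay is a number 3.3 percentage points higher from compound 2 to compound 3 (within the scatter), that is, none beyond the scatter. Compound 3 is accordingly estimated at 86% in this assay, within 72% to 98%.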

Compound 3, a percentage reported as activity, at one concentration (the size of the read-out at that concentration, not a potency): 89.7%
Compound 3: the middle estimate sits 3.7 percentage points below what was measured; the measured number falls inside the stated range.
By their numbers in this assay, from the lowest: compounds 2, 3 and 1 (each within the scatter of the next).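

In this assay, the group on an oxygen on a saturated carbon can lose its six-membered carbon ring: 2,3-dihydroxypropyl in place of 4,6-diamino-2,3-dihydroxycyclohexyl gives a number 7 percentage points higher from compound 2 to compound 3 (within the scatter) in this exchange, so neither the ring nor its nitrogens produce a step beyond the scatter. The open-chain group can also be cut further out, since hydroxy in place of (3-hydroxypropyl)amino on a saturated chain carbon, two bonds along the chain from an oxygen on a saturated carbon, gives a number 0.2 percentage points lower from compound 1 to compound 3 (within the scatter) on the shared core, which adds a change inside the chain to the ring exchange and again leaves the three compounds unordered on this read-out. No measurement in hand offers an explanation for these small steps.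

Still open, from the compounds shown here alone, is whether any group on this oxygen moves the read-out beyond the scatter, for instance a carboxylic acid at the end of the chain, a guanidine in place of the amine, or a plain methyl ether. Also open, going by these compounds, is whether a longer chain in place of the two ether chains on the shared core would change the picture, since these stay the same in compounds 1, 2 and 3.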